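Oxyimino chain terminus and compound 4 in the series

A few compounds are considered here, and "the series" means these few. Any claim that something is new, unique, unknown or untested is made for them only; others in the source may bear on it.

Measured compounds:
compound 1, `O=C(O)CCCO/N=c1/ccn([C@@H]2O[C@H](COP(=O)(O)OP(=O)(O)OP(=O)(O)O)[C@@H](O)[C@H]2O)c(=O)[nH]1`, 697 nM
compound 2, `O=c1[nH]/c(=N\OCCCc2ccc(I)cc2)ccn1[C@@H]1O[C@H](COP(=O)(O)OP(=O)(O)OP(=O)(O)O)[C@@H](O)[C@H]1O`, 90 nM
compound 3, `O=c1[nH]/c(=N\OCCCc2cccnc2)ccn1[C@@H]1O[C@H](COP(=O)(O)OP(=O)(O)OP(=O)(O)O)[C@@H](O)[C@H]1O`, 2950 nM

In a functional assay on 1321-N1 cells for agonist activity at P2Y purinoceptor 6 (Homo sapiens), read by scintillation counting and inositol phosphate accumulation (on this read-out lower numbers stand for an effect already at smaller amounts and higher numbers for an effect only at larger amounts of compound), compound 1 has the second highest of the three numbers; compound 2 lies nearest below it and compound 3 above it. Compound 4, `C#CCCCO/N=c1/ccn([C@@H]2O[C@H](COP(=O)(O)OP(=O)(O)OP(=O)(O)O)[C@@H](O)[C@H]2O)c(=O)[nH]1`, is not yet measured. It differs from compound 1 in one place: ethynyl in place of carboxy on a saturated chain carbon, three bonds along the chain from an oxygen on an unsaturated carbon. The steps at this position are a 7.7-fold lower number from compound 1 to compound 2 (0.89 log units; beyond the scatter) and a 4.2-fold higher number from compound 1 to compound 3 (0.63 log units; beyond the scatter), so exchanging the carboxy for an aryl group has moved the number in both directions, each time beyond the scatter. Among the measured compounds shown here, an ethynyl terminus has no measured counterpart here; without a clear precedent, the expected step for compound 4 is a 1.4-fold lower number from compound 1 to compound 4 (0.14 log units; within the scatter), and compound 4 is estimated at 500 nM, with a range from 150 nM to 2000 nM.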

Compound 4, half-maximal effective concentration: 3000 nM
Estimate against measurement, compound 4: 6.0-fold (0.78 log units) below; measured number outside the range, above it.
By their numbers in this assay, from the lowest: compound 2; then compound 1; then compounds 3 and 4 (each within the scatter of the next).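

In this assay a terminus without a ring does not match carboxy either, with a 4.3-fold higher number from compound 1 to compound 4 (0.63 log units; beyond the scatter) on this chain. Pent-4-yn-1-yl and the pyridin-3-yl-bearing chain cannot be told apart, with a 1.0-fold higher number from compound 3 to compound 4 (0.01 log units; within the scatter) within the scatter, so a ring at the terminus is not needed to reach this level. Only 4-iodophenyl gives a lower number than carboxy, with a 33-fold higher number from compound 2 to compound 4 (1.52 log units; beyond the scatter) here, and compounds 3 and 4 go against any general gain from replacing carboxy.

As far as these compounds go, whether compound 2 owes its number to the iodine or to the phenyl ring stays open, as do an unsubstituted phenyl, an amine and a longer chain ending in ethynyl. Nothing available explains the ethynyl result.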